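The source may hold more compounds than are shown below. What is called first, only, known or untested is meant among the compounds shown, and "the series" means these compounds.

Three compounds have so far been measured in an in vitro assay on 293-EBNA cells for binding affinity to corticotropin-releasing factor receptor 1 (Homo sapiens); a lower number here means a stronger inhibitor, a higher number a weaker inhibitor:

Compound 1 `CCC(COC)N(C)c1nc(C)nc2c1nnn2-c1ccc(C(C)C)cc1Br`: 11.2 nM
Compound 2 `COCCNc1nc(C)nc2c1nnn2-c1c(C)cc(C)cc1C`: 1200 nM
Compound 3 `CCCCN(CC)c1nc(C)nc2c1nnn2-c1ccc(SC)cc1Br`: 10.6 nM

Compound 1 stands second highest of the three numbers. Compound 3 lies nearest to it, and the two values fall within the usual scatter of each other, so no order between compound 1 and compound 3 can be claimed. Compound 2 lies furthest away, with a number far higher than that of compound 1 and well beyond the scatter. For the measured compounds named here, no two of these three compounds differ in a single place, so no isolated step is available to guide the next change.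

Compound 4 `CCC(CC)Oc1nc(C)nc2c1nnn2-c1ccc(C(C)C)cc1Br` has not yet been measured in this assay. It differs from compound 1 in one place: a group of 6 heavy atoms (5 carbon, 1 oxygen; no ring) in place of a group of 8 heavy atoms (6 carbon, 1 nitrogen, 1 oxygen; no ring), on an aromatic carbon. Going by the values given here, with no measured step of this kind among the three compounds, the size of the change can only be judged loosely. The expectation is a weakening somewhat beyond the scatter, though not a large one, and the estimated step is a 2.7-fold higher number from compound 1 to compound 4 (0.43 log units; beyond the scatter). Compound 4 is expected to give about 30 nM, within a range from 8 nM to 120 nM.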

Compound 4, inhibition constant: 1.9 nM
For compound 4 the middle estimate is 16-fold (1.20 log units) above the measured one; the measured number lies below the stated range.
By their numbers in this assay, from the lowest: compound 4; then compounds 3 and 1 (each within the scatter of the next); then compound 2.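

In this assay, for the compounds shown here, putting (pentan-3-yl)oxy in place of the group of 8 heavy atoms gives a 5.9-fold lower number from compound 1 to compound 4 (0.77 log units; beyond the scatter), the first single-place step at this position next to the ring nitrogen. The entering group has fewer heavy atoms and one hydrogen-bond acceptor fewer, yet the number fell, so for this pair neither the larger group nor its nitrogen is required for a low number. Nothing measured here explains why the number fell.

This single step changes the linking atom and the chain together, so the compounds shown cannot separate the two. As far as these compounds go, whether a pentan-3-yl group joined through sulfur, or an ether with a longer chain or a cyclopentyl ring, would go further remains open, as does whether the same exchange would carry over to compound 3.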